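A few compounds are considered here, and "the series" means these few. Any claim that something is new, unique, unknown or untested is made for them only; others in the source may bear on it.

Compound 1 (`CCCCCOC(=O)N1CCN(C(=O)[C@H](CCC(=O)O)NC(=O)c2cc(N3CCC(C(=O)N(CC)CC)CC3)nc(-c3ccccc3)n2)CC1`) gives > 80% in an ADME assay on microsomes from liver (Rattus norvegicus) for metabolic stability (a lower number here means that less of the compound is left, a higher number that more of the compound is left), and this is a limit of the assay, not a number. Compound 2 (`CCCCCOC(=O)N1CCN(C(=O)[C@H](CCC(=O)O)NC(=O)c2cc(N3CCC(C(=O)NCC)CC3)nc(-c3ccccc3)n2)CC1`) gives > 80%, which is also a limit. The evidence so far is therefore thin: the limit of > 80% in this assay, at which 2 of the 2 values shown sit. Among the measured compounds shown here, the only measured step is a step that the two limits leave unreadable from compound 1 to compound 2. It alters the diethylcarbamoyl group but provides no size to carry forward.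

Compound 3 (`CCCCCOC(=O)N1CCN(C(=O)[C@H](CCC(=O)O)NC(=O)c2cc(N3CCC(OCCO)CC3)nc(-c3ccccc3)n2)CC1`) has 2-hydroxyethoxy in place of diethylcarbamoyl on a saturated ring carbon. This replaces the whole group, a larger change than the measured one, and the data give no direction for it. No shift beyond the usual scatter is expected in this assay.

The estimated step is a step that the limit leaves unreadable from compound 1 to compound 3. Compound 3 is expected at 85%, within an estimated range of 65% to 97%.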

Compound 3, percent of the compound remaining: > 80%
Compound 3: no number, only a limit (the forecaster's own chance of this, stated with the estimate: 55%); the middle value is on the limit's open side.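

Neither the step between compound 1 and compound 3 nor the step between compound 2 and compound 3 can be read, because every value is a limit: the limit of > 80% in this assay, at which 3 of the 3 values shown sit.

The compounds shown leave open whether compound 1, compound 2 and compound 3 differ at all in this assay, and which group on the saturated ring carbon, if any, would lower the percent remaining.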